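This account rests on a few compounds, and the source may have more. Where it says the series, first, only, none or still open, it means among the compounds named here.

Compound 3 `CC(C)=CCc1cc(C(=O)Nc2cc3ccc(OCCCNCC(N)=O)c(C)c3oc2=O)ccc1O` sits second highest of the three numbers measured in a functional assay on MCF7 cells (Homo sapiens) for antiproliferative activity (a lower number here means a stronger inhibitor, a higher number a weaker inhibitor), where compound 3 gives 1460 nM; its nearest neighbour is compound 1 `CC(C)=CCc1cc(C(=O)Nc2cc3ccc(OCCCN4CCCC4)c(C)c3oc2=O)ccc1O`, for which compound 1 gives 990 nM, and its furthest is compound 2 `CC(C)=CCc1cc(C(=O)Nc2cc3ccc(OCCCNCC(=O)O)c(C)c3oc2=O)ccc1O`, for which compound 2 gives 18100 nM. The step from compound 3 to compound 4 `CC(C)=CCc1cc(C(=O)Nc2cc3ccc(OCCCN[C@@H]4C[C@H]5CC[C@@H]4C5)c(C)c3oc2=O)ccc1O` replaces the carbamoylmethyl group on the amine nitrogen: a group of 7 heavy atoms (7 carbon; 2 five-membered non-aromatic rings of carbon only) in place of a group of 4 heavy atoms (2 carbon, 1 nitrogen, 1 oxygen; no ring), on an amine nitrogen. The measured steps that bear on it are an 18-fold higher number from compound 1 to compound 2 (1.26 log units; beyond the scatter), a 12-fold lower number from compound 2 to compound 3 (1.09 log units; beyond the scatter) and a 1.5-fold higher number from compound 1 to compound 3 (0.17 log units; within the scatter). The two large steps both involve the carboxymethyl group of compound 2, which is absent from both compound 3 and compound 4; the remaining comparison, between a ring of carbon only and the carbamoylmethyl group, was within the scatter. Compound 4 carries a group of carbon only, as does compound 1, so no step beyond the scatter is expected; the step of a 1.6-fold lower number from compound 3 to compound 4 (0.21 log units; within the scatter) is estimated as small. Compound 4 is accordingly expected to give about 900 nM, within the range 300 nM to 3000 nM.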

Compound 4, half-maximal inhibitory concentration: 1030 nM
Compound 4: middle estimate off by 1.1-fold (0.06 log units), on the low side, and the stated range covers the measured number.
By their numbers in this assay, from the lowest: compounds 1, 4 and 3 (each within the scatter of the next); then compound 2.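

In this assay, a group of 7 carbon atoms in 2 five-membered non-aromatic rings, with 3 defined stereocentres, can stand on the amine nitrogen with no step beyond the scatter from the carbamoylmethyl group (a 1.4-fold lower number from compound 3 to compound 4 (0.15 log units; within the scatter)). The same holds against the pyrrolidin-1-yl compound (a 1.0-fold higher number from compound 1 to compound 4 (0.02 log units; within the scatter)), so groups with no ring, one ring or two rings all give numbers within the scatter of one another here. Compound 2, with its carboxymethyl group, remains the one compound set apart, and the new comparison confirms this with a large step (an 18-fold lower number from compound 2 to compound 4 (1.24 log units; beyond the scatter)); no evidence shown accounts for any of these steps.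

As far as these compounds go, whether the 3 defined stereocentres matter stays open, since only one arrangement of them appears. From the compounds shown here alone, it is also open whether a morpholine ring on the saturated chain carbon, or a longer chain, would give a number in the same range.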